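A few compounds are considered here, and "the series" means these few. Any claim that something is new, unique, unknown or untested is made for them only; others in the source may bear on it.

Among the measured compounds shown here, compound 2 `COc1cc(OC)c2c(=O)cc(-c3ccc(OC4CCN(C)CC4)cc3)oc2c1` holds the only number recorded here: in a functional assay (Homo sapiens) for antiproliferative activity, read by resazurin assay, with a stated time of 48 h, tested at 10 uM (a higher number here means a stronger effect of the compound at the concentration tested, a lower number a weaker effect), compound 2 gives 49%. Compound 1 `COc1cc(OC)c2c(=O)cc(-c3ccc(OCCBr)cc3)oc2c1` is reported in this assay only as "not active" (no number reported), so its result cannot be set against compound 2 in numbers. Compound 3 `COc1cc(OC)c2c(=O)cc(-c3ccc(OCCCN)cc3)oc2c1` differs from compound 2 in a single place: 3-aminopropyl in place of 1-methylpiperidin-4-yl on an oxygen on an aromatic ring. For the measured compounds named here, no step between measured compounds is available to guide this change. A small downward step from a number 9 percentage points lower from compound 2 to compound 3 (within the scatter) is expected, one that stays within the usual scatter of this measurement. Compound 3 is therefore estimated at 40%, with a likely range from 15% to 65% in this assay.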

Compound 3, a percentage reported as inhibition, at one concentration (the size of the read-out at that concentration, not a potency): 39%
For compound 3 the middle estimate is 1 percentage points above the measured one; the measured number falls inside the stated range.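

Across this assay, the step on this oxygen reads a number 10 percentage points lower from compound 2 to compound 3 (within the scatter). Replacing the 1-methylpiperidin-4-yl ring with the 3-aminopropyl chain, which has no ring and carries a hydrogen-bond donor, therefore gives no change that can be told from the scatter. Among the compounds shown here, this is the first numerical comparison at this position, since compound 1 has no number to set against either compound. No measurement shown here explains this result. The compounds shown leave open what a carboxylic acid, a dimethylamine or a longer amine chain on this oxygen would give.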